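Removing the Trifluoromethyl Group: From Compound 3 to Compound 4

The source may report more compounds than this note shows. Statements on the series, on what has been measured and on what is new or still open speak of the compounds shown alone.

Compound 3 `O=C(NCc1ccc(C(F)(F)F)cc1)N1C(=O)c2ccccc2S1(=O)=O` stands second highest of three in a physicochemical assay for pharmacokinetics (a lower number here means that the compound disappears faster, a higher number that the compound lasts longer), giving 0.212 h; compound 1 `O=C(NCc1cccs1)N1C(=O)c2ccccc2S1(=O)=O` gives 0.365 h and compound 2 `COc1ccc(CNC(=O)N2C(=O)c3ccccc3S2(=O)=O)cc1` gives 0.187 h. The measured steps were both small, with a 2.0-fold lower number from compound 1 to compound 2 (0.29 log units; within the scatter). Compound 4 `O=C(NCc1ccccc1)N1C(=O)c2ccccc2S1(=O)=O` differs from compound 3 by hydrogen in place of trifluoromethyl on an aromatic carbon. Going by the values given here, only one measured step bears on this change, because a 1.1-fold higher number from compound 2 to compound 3 (0.05 log units; within the scatter) also replaced a group on an aromatic carbon and stayed within the scatter. Among the compounds with values here, no measured step removes a group altogether, so the change from trifluoromethyl to hydrogen has no direct precedent here. Compound 4 is therefore expected to show no step beyond the scatter, a 1.0-fold higher number from compound 3 to compound 4 (0.02 log units; within the scatter). Compound 4 is estimated at 0.22 h, with a range from 0.11 h to 0.44 h.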

Compound 4, half-life: 1.02 h
Beside the measured number, compound 4's estimate is 4.6-fold (0.67 log units) below it; the measured number lies above the stated range.
By their numbers in this assay, from the lowest: compounds 2, 3 and 1 (each within the scatter of the next); then compound 4.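

In this assay hydrogen on this aromatic carbon gives a 4.8-fold higher number from compound 3 to compound 4 (0.68 log units; beyond the scatter) against trifluoromethyl and a 5.5-fold higher number from compound 2 to compound 4 (0.74 log units; beyond the scatter) against methoxy, while those two groups stay within the scatter of each other. Phenyl in place of thiophen-2-yl on the saturated chain carbon gives a 2.8-fold higher number from compound 1 to compound 4 (0.45 log units; beyond the scatter) as well, so compound 4 alone lies beyond the scatter of all the others. Among these compounds, both groups tested on this aromatic carbon go with a shorter half-life than hydrogen. No measurement shown here accounts for the rise. Going by these compounds, whether fluorine, methyl or an amine on this carbon would keep the higher number stays open.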